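The compounds below may be only part of what the source reports. "The series", "measured", "known", "first", "only" and "open" are said of these compounds alone.

Compound 1 `COc1ccc(C2=NN(C3=NC(=O)/C(=C4\C(=O)Nc5ccc(Br)cc54)S3)C(c3ccc(OC)cc3)C2)cc1` and compound 2 `COc1ccc(C2=NN(C3=NC(=O)/C(=C4\C(=O)Nc5ccc(Cl)cc54)S3)C(c3ccc(OC)cc3)C2)cc1` share a core and differ in a single spot, (chloro in place of bromo on an aromatic carbon). In a functional assay on cells (Cancer cell lines, Homo sapiens) for cytotoxicity, read by sulforhodamine B assay, with a stated time of 48 h (a higher number here means a weaker inhibitor of growth, a lower number a stronger inhibitor of growth), compound 1 gives 430 nM, while compound 2 gives 440 nM; the step of a 1.0-fold higher number from compound 1 to compound 2 (0.01 log units; within the scatter). Compound 3 `CN(C)c1ccc(C2CC(c3ccccc3)=NN2C2=NC(=O)/C(=C3\C(=O)Nc4ccc(Br)cc43)S2)cc1` is built on a different core, and the difference between the two cores is not broken down here. In this assay compound 3 gives 540 nM. Compound 4 `CN(C)c1ccc(C2CC(c3ccccc3)=NN2C2=NC(=O)/C(=C3\C(=O)Nc4ccc(Cl)cc43)S2)cc1` has not yet been measured; it differs from compound 3 by chloro in place of bromo on an aromatic carbon, the same change and at the same place as between compound 1 and compound 2. Because a 1.0-fold higher number from compound 1 to compound 2 (0.01 log units; within the scatter) was flat, the step to compound 4 is expected to be about as flat, a 1.0-fold higher number from compound 3 to compound 4 (0.01 log units; within the scatter). Compound 4 is therefore estimated at 550 nM, expected between 300 nM and 1000 nM.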

Compound 4, concentration for total growth inhibition: 510 nM
Beside the measured number, compound 4's estimate is 1.1-fold (0.03 log units) above it; low and high end bracket the measured number.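

In this assay, chloro in place of bromo gives a 1.1-fold lower number from compound 3 to compound 4 (0.02 log units; within the scatter), so on this second core the swap is again flat. Set beside the first core, the two steps agree: the same change on two cores in this assay, a 1.0-fold higher number (0.01 log units; within the scatter) from compound 1 to compound 2 and a 1.1-fold lower number (0.02 log units; within the scatter) from compound 3 to compound 4, 1.1-fold (0.03 log units) apart, within the scatter of two such steps. Going by these compounds alone, this shows that the flat result carried over between these two cores, but it covers only one exchange of halogens at one place in one assay, and it does not explain the flatness or predict the result on any other core.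

The compounds shown leave open whether fluoro, or a quite different group such as an amine or a carboxylic acid, would be just as flat at this place. They also leave open whether any such group would behave alike on both cores.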